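The compounds below may be only part of what the source reports. "The series", "measured", "known", "first", "only" and "open" are said of these compounds alone.

Compound 2 `C=CCn1c(=O)/c(=C\c2cccc(Cl)c2Cl)[nH]c(=O)/c1=C\c1ccccc1OC` stands lowest of the two numbers in hand in a functional assay on NCI-H1975 cells (Homo sapiens) for cytotoxicity, read by CCK-8 assay, with a stated time of 72 h (a higher number here means a weaker inhibitor, a lower number a stronger inhibitor), with compound 2 giving 4500 nM. Compound 1 `COc1ccccc1/C=c1/[nH]c(=O)/c(=C\c2ccccc2OC)n(C)c1=O` gives 16900 nM, a higher number beyond the scatter. Compound 3 `COc1ccccc1/C=c1\c(=O)[nH]/c(=C/c2cccc(Cl)c2Cl)c(=O)n1C` is not yet measured and differs from compound 2 by hydrogen in place of vinyl on a saturated chain carbon bound to an aromatic nitrogen, allyl to methyl. Among the compounds with values here, no measured pair follows this change alone, so the size of the step is uncertain; a small loss, perhaps within the scatter, is expected. Compound 3 is estimated at 6500 nM, range 2500 nM to 16000 nM, meaning an expected step of a 1.4-fold higher number from compound 2 to compound 3 (0.16 log units; within the scatter).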

Compound 3, half-maximal inhibitory concentration: 300 nM
Beside the measured number, compound 3's estimate is 22-fold (1.34 log units) above it; measured number outside the range, below it.
By their numbers in this assay, from the lowest: compound 3; then compound 2; then compound 1.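

In this assay, this position proves sensitive: allyl to methyl, hydrogen in place of vinyl on a saturated chain carbon bound to an aromatic nitrogen, gives a 15-fold lower number from compound 2 to compound 3 (1.18 log units; beyond the scatter). The aryl group also counts, with 2,3-dichlorophenyl in place of 2-methoxyphenyl on a double-bonded chain carbon bound to an aromatic carbon giving a 56-fold lower number from compound 1 to compound 3 (1.75 log units; beyond the scatter). Nothing at hand accounts for the size of either step.

On these data alone, only allyl and methyl can be compared here, so it remains open how an ethyl group, a longer chain or a chain ending in an amine would read.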